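Chloroalkyl amide chain length on the shared core

The source may report more compounds than this note shows. Statements on the series, on what has been measured and on what is new or still open speak of the compounds shown alone.

The series keeps one core and varies the acyl group of the anilide. Compound 1 `CCCC(=O)Nc1ccc(S(=O)(=O)Oc2ccccc2C(C)C)cc1` gives 4900 nM in a functional assay on HT-29 cells (Homo sapiens) for antiproliferative activity, read by sulforhodamine B assay, with a stated time of 48 h; a higher number here means a weaker inhibitor, a lower number a stronger inhibitor. Compound 2 `CC(C)C(=O)Nc1ccc(S(=O)(=O)Oc2ccccc2C(C)C)cc1` gives 14000 nM in this assay, and compound 3 `CC(C)c1ccccc1OS(=O)(=O)c1ccc(NC(=O)CCl)cc1` gives 5600 nM. Compound 3 therefore stands second highest of the three numbers; its nearest neighbour is compound 1, and that gap, a 1.1-fold higher number from compound 1 to compound 3 (0.06 log units; within the scatter), is within the scatter, while the gap to compound 2, a 2.5-fold lower number from compound 2 to compound 3 (0.40 log units; beyond the scatter), is beyond it. Branching on the carbonyl carbon, a 2.9-fold higher number from compound 1 to compound 2 (0.46 log units; beyond the scatter), weakens inhibition modestly.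

Compound 4 `CC(C)c1ccccc1OS(=O)(=O)c1ccc(NC(=O)CCCCl)cc1` differs from compound 3 by 2-chloroethyl in place of chloro on a saturated chain carbon bound to a carbonyl carbon. The step that bears most directly on this change is a 1.1-fold higher number from compound 1 to compound 3 (0.06 log units; within the scatter), where chloro in place of ethyl at the same place left the number within the scatter; compound 4 resembles compound 1 with 3-chloropropyl in place of propyl. No branching enters, so a 2.9-fold higher number from compound 1 to compound 2 (0.46 log units; beyond the scatter) does not apply. For compound 4 the expected step, a 1.1-fold lower number from compound 3 to compound 4 (0.05 log units; within the scatter), is thus none beyond the scatter. Compound 4 is estimated at 5000 nM, with a range of 2000 nM to 13000 nM.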

Compound 4, half-maximal inhibitory concentration: 6200 nM
Compound 4: middle estimate off by 1.2-fold (0.09 log units), on the low side; measured number inside the range.
By their numbers in this assay, from the lowest: compounds 1, 3 and 4 (each within the scatter of the next); then compound 2.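

Chloromethyl and 3-chloropropyl on the carbonyl carbon read alike in this assay (a 1.1-fold higher number from compound 3 to compound 4 (0.04 log units; within the scatter)), and chloro in place of hydrogen on a saturated chain carbon, three bonds along the chain from a carbonyl carbon, also stays within the scatter (a 1.3-fold higher number from compound 1 to compound 4 (0.10 log units; within the scatter)). Compound 2 remains apart from the 3-chloropropyl amide (a 2.3-fold lower number from compound 2 to compound 4 (0.35 log units; beyond the scatter)), so among these four compounds the unbranched acyl groups of compounds 1, 3 and 4 form one group of numbers, with the isopropyl of compound 2 as the only one outside it. No measurement at hand explains why the chain and its chlorine make so little difference here.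

From the compounds shown here alone, a longer chain remains open. So does an amine or a carboxylic acid in place of the chloro on the chain.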